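The source may report more compounds than this note shows. Statements on the series, on what has been measured and on what is new or still open speak of the compounds shown alone.

In a functional assay on HL-60 cells (Homo sapiens) for inhibition, read by resazurin assay, with a stated time of 72 h (on this read-out lower numbers stand for stronger inhibition and higher numbers for weaker inhibition), three compounds of the series have been measured so far. Compound 3 `CCSc1ccc(C2C(O)C(=O)N2c2cc(OC)c(OC)c(OC)c2)cc1` gives 16 nM, the lowest of the three numbers. Compound 1 `COc1cc(N2C(=O)CC2c2ccc(SC)cc2)cc(OC)c1OC` gives 69 nM, and compound 2 `CCSc1ccc(C2C(Oc3ccccc3)C(=O)N2c2cc(OC)c(OC)c(OC)c2)cc1` gives 508 nM.

Compound 4 `CCSc1ccc(C2CC(=O)N2c2cc(OC)c(OC)c(OC)c2)cc1` is the next case, with this change from compound 3: hydrogen in place of hydroxy on a saturated ring carbon. In words, hydrogen replaces hydroxy on a saturated ring carbon. Among the measured compounds shown here, the only measured step at this ring carbon is a 32-fold lower number from compound 2 to compound 3 (1.50 log units; beyond the scatter), which is large. That step swaps phenyl for hydrogen on the oxygen and keeps the oxygen, so it does not size the loss of the hydroxy itself.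

The chain on the sulfur differs between compound 4 and compound 1, but compound 1 also carries no substituent on this ring carbon, and it gives 69 nM. A moderate rise in this assay is therefore expected, much smaller than the measured step. The expected size is a 2.8-fold higher number from compound 3 to compound 4 (0.45 log units; beyond the scatter). For compound 4 the estimated value is 45 nM, with an expected range of 15 nM to 140 nM.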

Compound 4, half-maximal inhibitory concentration: 204 nM
Compound 4: the middle estimate sits 4.5-fold (0.66 log units) below what was measured; measured number above the stated range.
By their numbers in this assay, from the lowest: compound 3; then compound 1; then compound 4; then compound 2.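

In this assay there is a 13-fold higher number from compound 3 to compound 4 (1.11 log units; beyond the scatter) when hydrogen replaces hydroxy, so the free hydroxy on this saturated ring carbon gives a far lower number than no substituent at all. Phenoxy at the same carbon goes the other way, with a 2.5-fold lower number from compound 2 to compound 4 (0.40 log units; beyond the scatter) on its replacement by hydrogen, which orders the three substituents as hydroxy lowest, then hydrogen, then phenoxy. With hydrogen on this ring carbon the chain on the sulfur also matters, with a 3.0-fold higher number from compound 1 to compound 4 (0.47 log units; beyond the scatter) on adding the methyl.

Still open, going by these compounds, is where an amine or a methoxy group on this ring carbon would fall in that order, and whether the hydroxy step holds with the shorter chain of compound 1. No measurement at hand explains these differences.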